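The source may report more compounds than this note shows. Statements on the series, on what has been measured and on what is new or still open speak of the compounds shown alone.

The shared core carries an amide-type nitrogen that bears a varied aryl group. Compound 1 `Cc1cc(NC(=O)Nc2ncccc2C)c2ccccc2n1` carries the 3-methylpyridin-2-yl group. In an ADME assay on Raji cells (Homo sapiens) for cytotoxicity, with a stated time of 72 h (on this read-out lower numbers stand for an effect already at smaller amounts and higher numbers for an effect only at larger amounts of compound), compound 1 reaches only a limit, > 25000 nM. For the measured compounds named here, compound 2 `Cc1cc(NC(=O)Nc2cccc(Cl)c2)c2ccccc2n1` carries the 3-chlorophenyl group; in this assay compound 2 gives 18000 nM, the only value here that is a number rather than a limit. Compound 3 `Cc1cc(NC(=O)Nc2ccc(O)cc2)c2ccccc2n1` carries the 4-hydroxyphenyl group. In this assay compound 3 again reaches only a limit, > 25000 nM. This places compound 3 at the limit of > 25000 nM in this assay, at which 2 of the 3 values shown sit. The steps into compound 3 are a step that the two limits leave unreadable from compound 1 to compound 3 and an at least 1.3-fold higher number from compound 2 to compound 3 (0.14 log units; that floor lies within the scatter), and between the other two stands an at least 1.3-fold lower number from compound 1 to compound 2 (0.14 log units; that floor lies within the scatter); all three exchange whole aryl groups, none exchanges a single substituent on a ring that stays.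

Compound 4 `Cc1cc(NC(=O)Nc2ccc(C(C)(C)C)cc2)c2ccccc2n1` differs from compound 3 by tert-butyl in place of hydroxy on an aromatic carbon. Going by the values given here, no measured step exchanges one substituent for another on the same ring, so nothing measured bears directly on this change; the only guide is that the whole series sits at the limit or close to it, the one numbered value, that of compound 2, included. The step of an at least 1.2-fold lower number from compound 3 to compound 4 (0.09 log units; that floor lies within the scatter) is therefore expected to be small, with no direction that can be read beyond the scatter. Compound 4 is estimated at 20000 nM, between 8000 nM and 50000 nM, with a fair chance that only a limit is recorded.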

Compound 4, half-maximal effective concentration: > 25000 nM
Compound 4: only a limit was reported; the forecaster's own chance of this, stated with the estimate: 50%; middle value at least 1.2-fold (0.09 log units) from the limit.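

In this assay compound 3 and compound 4 both reach only a limit, and the step between them cannot be read. The series now stands at: the limit of > 25000 nM in this assay, at which 3 of the 4 values shown sit.

The compounds shown leave open whether tert-butyl and hydroxy on this ring differ at all in this read-out, and what numbers compound 1, compound 3 and compound 4 would take.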